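The source may hold more compounds than are shown below. What is called first, only, known or untested is meant among the compounds shown, and "the series" means these compounds.

Measured compounds:
- compound 1 `Cc1ccc(CS/C(=C/c2ccc(O)cc2)C(=O)c2ccc(Cl)cc2)cc1` — 10000 nM
- compound 3 `O=C(/C(=C\c1ccc(O)cc1O)Sc1ccccc1Br)c1ccc(Br)cc1` — 50000 nM
- compound 2 `COc1cc(OC)c(/C=C(\C(=O)c2ccc(Br)cc2)S(=O)(=O)c2ccc(Br)cc2)c(OC)c1` — reported only as a limit, > 100000 nM

All three share a core in which a carbonyl sits on one end of a double-bonded chain, an aryl sulfur group on the same chain carbon, and an aromatic ring on the other chain carbon. In a functional assay on DU-145 cells (Homo sapiens) for inhibition, read by trypan blue exclusion, with a stated time of 96 h (a higher number here means a weaker inhibitor of growth, a lower number a stronger inhibitor of growth), compound 1 gives 10000 nM, the lowest of the two numbers actually recorded. Compound 3 gives 50000 nM in this assay, a higher number that lies beyond the scatter of repeated measurements. For compound 2, this assay records only a limit, (the limit of > 100000 nM in this assay, at which 1 of the 3 values shown sits), so no number can be set against it.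

Compound 4 `Cc1ccc(CS/C(=C/c2ccc(C)s2)C(=O)c2ccc(Cl)cc2)cc1` has not yet been measured. It differs from compound 1 in one place: 5-methylthiophen-2-yl in place of 4-hydroxyphenyl on a double-bonded chain carbon bound to a double-bonded chain carbon. For the measured compounds named here, no measured pair here shows the effect of such a swap, so the expectation rests only on compound 1 and on the structural change. Losing the hydroxyl of the 4-hydroxyphenyl group removes the only hydrogen-bond donor, and a modest weakening is expected, roughly at the edge of the scatter. Compound 4 is expected to give 20000 nM in this assay, with a range from 5000 nM to 80000 nM. That estimate corresponds to an expected step of a 2.0-fold higher number from compound 1 to compound 4 (0.30 log units; within the scatter), toward weaker inhibition of growth.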

Compound 4, concentration for 50% growth inhibition: 50000 nM
For compound 4 the middle estimate is 2.5-fold (0.40 log units) below the measured one, within the range that was stated.
By their numbers in this assay, from the lowest: compound 1; then compounds 3 and 4 (each within the scatter of the next). At a limit, above all of these: compound 2.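

In this assay, putting 5-methylthiophen-2-yl in place of 4-hydroxyphenyl on a double-bonded chain carbon bound to a double-bonded chain carbon gives a 5.0-fold higher number from compound 1 to compound 4 (0.70 log units; beyond the scatter), the first direct view of a single change in this series, and it shows that growth inhibition responds to what sits at this position. The swap alters several things at once: a six-membered aromatic ring of carbon only gives way to a five-membered aromatic ring with a sulfur atom, a methyl group arrives, and the hydroxyl goes, leaving 0 hydrogen-bond donors in the entering group where the leaving group has 1. Nothing in the data shown accounts for the size of this step.

Going by these compounds, it remains open whether the weakening follows from losing the hydroxyl or from changing the ring, a question that a plain phenyl or an unsubstituted thiophen-2-yl at this place could help to separate. Also open, on these data alone, are how a 4-aminophenyl group would compare here and whether the same swap would have a similar effect with a different group on the sulfur.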